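The source may hold more compounds than are shown below. What is called first, only, known or untested is meant among the compounds shown, and "the series" means these compounds.

Measured in a functional assay on T-24 cells (Homo sapiens) for antiproliferative activity, read by sulforhodamine B assay, with a stated time of 72 h; a lower number here means a stronger inhibitor, a higher number a weaker inhibitor:
- compound 1 `CCCSC(=O)COC(=O)C1=C2C(=NC1=O)c1cccc3cccc2c13`: 10500 nM
- compound 2 `O=C(COC(=O)C1=C2C(=NC1=O)c1cccc3cccc2c13)OCC(F)(F)C(F)(F)F`: 19000 nM

Among the compounds with values here, only these two compounds have numbers so far, and they cannot be ranked, since the step is a 1.8-fold higher number from compound 1 to compound 2 (0.26 log units; within the scatter). Within the data shown here, compound 1 therefore stands level with the only other measured compound, and both values lie in the same range.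

The next compound, compound 3 `CCCSC(=O)COC(=O)C1=C2C(=NC1=O)c1cccc3c(SCCC)ccc2c13`, keeps everything in compound 1 except for one change on the core: propylsulfanyl in place of hydrogen on an aromatic carbon. Among the measured compounds shown here, the one measured step does not bear directly on this change. For the measured compounds named here, it swaps 2,2,3,3,3-pentafluoropropoxy for propylsulfanyl on a carbonyl carbon, whereas the new group goes on an aromatic carbon, and no measured pair tests that place. The data therefore point to no direction, and no step beyond the scatter is expected in this assay, although the uncertainty is wide. The expectation starts from compound 1 at 10500 nM.

The estimate amounts to an expected step of a 1.3-fold lower number from compound 1 to compound 3 (0.12 log units; within the scatter).

For compound 3 the estimated value is 8000 nM, with an expected range from 2500 nM to 25000 nM.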

Compound 3, half-maximal inhibitory concentration: 79100 nM
Beside the measured number, compound 3's estimate is 9.9-fold (1.00 log units) below it, and the stated range ends below it.
By their numbers in this assay, from the lowest: compounds 1 and 2 (each within the scatter of the next); then compound 3.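

This aromatic carbon of the shared core is not a neutral place for a new group: in this assay the step of a 7.5-fold higher number from compound 1 to compound 3 (0.88 log units; beyond the scatter) shows that propylsulfanyl in place of hydrogen gives a weaker inhibitor. Within the data shown here, the only earlier comparison changed a group on a carbonyl carbon and stayed within the scatter, so this is the first single change here that clearly moves the number, although the move is modest in size. No measurement shown here explains why this substitution weakens the antiproliferative effect.

This result rests on one group at one position, so it does not show whether the size of the group, its sulfur atom or the position itself matters most. From the compounds shown here alone, it remains open whether a methylsulfanyl group, a longer chain or an amine on the same aromatic carbon would move the number in the same direction, and whether the step would hold with the 2,2,3,3,3-pentafluoropropoxy group of compound 2 on the carbonyl carbon.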